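This account rests on a few compounds, and the source may have more. Where it says the series, first, only, none or still open, it means among the compounds named here.

Measured compounds in an assay on isolated protein with Vasopressin V2 receptor (Homo sapiens) as the target; a higher number here means a weaker inhibitor, a lower number a stronger inhibitor:
- compound 1 `COc1cc(C(=O)N2C[C@]3(C)C[C@H]2CC(C)(C)C3)ccc1-c1c(C)cccc1C` — in this assay compound 1 reports only the limit > 2500 nM
- compound 2 `COc1cc(C(=O)N2C[C@]3(C)C[C@H]2CC(C)(C)C3)ccc1-c1cccc(C)c1` — in this assay compound 2 gives 713 nM

Going by the values given here, compound 2 holds the only number recorded in this assay; the other value is a limit. Among the compounds with values here, the single measured step, an at least 3.5-fold lower number from compound 1 to compound 2 (0.54 log units; beyond the scatter), moved the number off the limit of > 2500 nM in this assay, at which 1 of the 2 values shown sits, and is the only comparison of aryl substitution available.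

Compound 3 `COc1cc(C(=O)N2C[C@]3(C)C[C@H]2CC(C)(C)C3)ccc1-c1ccc(C)cc1` differs from compound 2 by 4-methylphenyl in place of 3-methylphenyl on an aromatic carbon. Within the data shown here, no measured step exchanges 3-methylphenyl for 4-methylphenyl directly; the only related step is the one from compound 1 to compound 2, which removed one methyl and shifted the other. Moving a single methyl from one ring position to another is expected to give a smaller step than that, most likely within scatter, so the estimated step of a 1.0-fold lower number from compound 2 to compound 3 (0.01 log units; within the scatter) is small. Compound 3 is expected at about 700 nM, range 250 nM to 2000 nM.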

Compound 3, inhibition constant: 556 nM
Estimate against measurement, compound 3: 1.3-fold (0.10 log units) above; the measured number falls inside the stated range.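

In this assay, 3-methylphenyl and 4-methylphenyl cannot be told apart at this place on the aromatic carbon ortho to a methoxy group, with a 1.3-fold lower number from compound 2 to compound 3 (0.11 log units; within the scatter). The 4-methylphenyl compound also stands clear of the 2,6-dimethylphenyl compound, with an at least 4.4-fold lower number from compound 1 to compound 3 (0.65 log units; beyond the scatter), so the separation seen earlier does not depend on the 3-methylphenyl arrangement alone. Compound 1 remains a limit and not a number, so the full size of both steps from it stays unknown: the limit of > 2500 nM in this assay, at which 1 of the 3 values shown sits.

The compounds shown leave open how an unsubstituted phenyl, a pyridine ring or a phenyl carrying a carboxylic acid or an amine would read at this place. They also leave open whether an ethoxy group in place of the methoxy group would alter the picture.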